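This account rests on a few compounds, and the source may have more. Where it says the series, first, only, none or still open, it means among the compounds named here.

In a physicochemical assay for lipophilicity, at pH 7.4 (on this read-out lower numbers stand for lower lipophilicity and higher numbers for higher lipophilicity), compound 3 `COc1ccc(CNCCCC[C@@H](Nc2cc(C)c(F)c(C)c2)C(=O)NO)cc1` gives < 3, which is a limit of the assay and not a number. Compound 1 `Cc1cc(N[C@H](CCCCNCc2ccccc2F)C(=O)NO)cc(C)c1F` gives < 3, also a limit. Compound 2 `Cc1cc(N[C@H](CCCCNCc2cccc(F)c2)C(=O)NO)cc(C)c1F` gives < 3, again a limit. Compound 4 `Cc1cc(N[C@H](CCCCNCCCc2ccc(F)cc2)C(=O)NO)cc(C)c1F` carries 2-(4-fluorophenyl)ethyl in place of 4-methoxyphenyl on a saturated chain carbon bound to an amine nitrogen. The measured steps that bear on this change are a step that the two limits leave unreadable from compound 1 to compound 3 and a step that the two limits leave unreadable from compound 2 to compound 3, along with a step that the two limits leave unreadable from compound 1 to compound 2. None has a readable size, so the expectation rests only on (the limit of < 3 in this assay, at which 3 of the 3 values shown sit). A small upward step is tentatively expected in this assay: a step that the limit leaves unreadable from compound 3 to compound 4. Compound 4 is estimated at 2.7, with an expected range from 2 to 3.3.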

Compound 4, distribution coefficient: < 3
Compound 4 was reported as a limit (the forecaster's own chance of this, stated with the estimate: 65%); the middle value lies beyond the limit too.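

The steps from compound 1, compound 2 and compound 3 to compound 4 cannot be read in this assay, as all four compounds give only a limit: the limit of < 3 in this assay, at which 4 of the 4 values shown sit.

The compounds shown leave open whether these changes shift the read-out at all.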